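A few compounds are considered here, and "the series" means these few. Any claim that something is new, unique, unknown or untested is made for them only; others in the source may bear on it.

In an ADME assay on the whole organism (Macaca fascicularis) for pharmacokinetics, read by LC-MS, using cassette dosing, at a dose of 1 mg/kg by the oral route (a higher number here means more compound in the circulation at the dose given, a lower number less compound in the circulation), compound 2 `Cc1ccc(-c2nc(=O)o[nH]2)c(-c2ccc([C@@H](C)N(CC3CC3)c3nc4c(C(=O)O)cccc4o3)cc2)c1` gives 2920 nM, the highest of the three numbers. Compound 1 `C[C@H](c1ccc(-c2cc(Cl)ccc2-c2nc(=O)o[nH]2)cc1)N(CC1CC1)c1nc2c(C(=O)O)cccc2o1` gives 976 nM in this assay, and compound 3 `CCCCN(c1nc2c(-c3nccn3C)cccc2o1)[C@H](C)c1ccc(-c2ccccc2-c2nnn[nH]2)cc1` gives 154 nM. Compound 4 `C[C@H](c1ccc(-c2cc(F)ccc2-c2nc(=O)o[nH]2)cc1)N(CC1CC1)c1nc2c(C(=O)O)cccc2o1` has not yet been measured; it differs from compound 2 by fluoro in place of methyl on an aromatic carbon. Among the measured compounds shown here, the only measured step at this position is a 3.0-fold higher number from compound 1 to compound 2 (0.48 log units; beyond the scatter), where methyl replaced chloro. Fluoro, like chloro, is a halogen, so part of that gain is expected to be given back. For compound 4 a modest step down in this assay is therefore expected, a 1.9-fold lower number from compound 2 to compound 4 (0.29 log units; within the scatter). Compound 4 is estimated at 1500 nM, with a range from 600 nM to 4000 nM.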

Compound 4, maximal plasma concentration: 2900 nM
Compound 4: the middle estimate sits 1.9-fold (0.29 log units) below what was measured; measured number inside the range.
By their numbers in this assay, from the lowest: compound 3; then compound 1; then compounds 4 and 2 (each within the scatter of the next).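

In this assay the step of a 1.0-fold lower number from compound 2 to compound 4 (0.00 log units; within the scatter) shows that fluoro and methyl cannot be told apart at this position. The second step of a 3.0-fold higher number from compound 1 to compound 4 (0.47 log units; beyond the scatter) is about the same size as a 3.0-fold higher number from compound 1 to compound 2 (0.48 log units; beyond the scatter) so, among these three groups, only chloro goes with the lower number, and being a halogen does not by itself set the value. Nothing available explains why chloro and fluoro differ here. On these data alone, whether plain hydrogen, methoxy, trifluoromethyl or an amine at this position would keep the number stays open. So does whether this swap behaves the same way on a different core.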